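The source may hold more compounds than are shown below. What is called first, only, known or untested is meant among the compounds shown, and "the series" means these compounds.

Measured so far:
Compound 1, `COC(=O)C1=C(c2ccc(C(C)(C)C)cc2)CCCC1`: 605000 nM
Compound 2, `COC(=O)C1=C(c2ccc(OC(F)(F)F)cc2)CCCC1`: 1660000 nM
Compound 3, `COC(=O)[C@@H]1CCCC[C@@H]1c1ccc(C(C)(C)C)cc1`: 766000 nM

All three were tested in an assay on COS-1 cells for displacement of a labelled ligand from sodium-dependent dopamine transporter (Homo sapiens); on this read-out higher numbers stand for weaker inhibition and lower numbers for stronger inhibition. Compound 1 and compound 3 share no counted difference; the difference between the two cores is not broken down here, and their values lie within the usual scatter of each other. Between compound 1 and compound 2 one change was made, (trifluoromethoxy in place of tert-butyl on an aromatic carbon), and it gave a 2.7-fold higher number from compound 1 to compound 2 (0.44 log units; beyond the scatter).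

Compound 4, `COC(=O)[C@@H]1CCCC[C@@H]1c1ccc(OC(F)(F)F)cc1`, has not yet been measured. It differs from compound 3 by trifluoromethoxy in place of tert-butyl on an aromatic carbon, the same change, at a place described in the same words. The step from compound 3 to compound 4 is therefore expected to be about as large as the earlier one, a 2.6-fold higher number from compound 3 to compound 4 (0.42 log units; beyond the scatter), because that is the size seen in a 2.7-fold higher number from compound 1 to compound 2 (0.44 log units; beyond the scatter). Compound 4 is thus estimated at 2000000 nM, with a range from 900000 nM to 5000000 nM.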

Compound 4, inhibition constant: 1180000 nM
Estimate against measurement, compound 4: 1.7-fold (0.23 log units) above; the range from low to high includes it.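

In this assay, putting trifluoromethoxy in place of tert-butyl gave a 1.5-fold higher number from compound 3 to compound 4 (0.19 log units; within the scatter), so this step alone cannot be told apart from repeat-measurement noise. Set beside the same change on the other core, the two steps do not differ beyond the scatter: the same change on two cores in this assay, a 2.7-fold higher number (0.44 log units; beyond the scatter) from compound 1 to compound 2 and a 1.5-fold higher number (0.19 log units; within the scatter) from compound 3 to compound 4, 1.8-fold (0.25 log units) apart, within the scatter of two such steps. The change therefore carried across these two cores with no detectable difference in size, but two pairs show neither that the steps are truly equal nor that the same would hold on any further core.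

As far as these compounds go, what remains open is how other groups at this position on the aromatic ring, such as an amine, a carboxylic acid or a longer chain, would behave on either core.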